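Spiro-fused series: methoxy for chloro, antiproliferative limit

A few compounds are considered here, and "the series" means these few. Any claim that something is new, unique, unknown or untested is made for them only; others in the source may bear on it.

Measured so far:
compound 1 `COc1ccccc1-n1nncc1CN1C(=O)C2(C(C#N)=C(N)Oc3c2c2nc4ccccc4nc2c2ccccc32)c2ccccc21` — > 50000 nM, a limit of the assay
compound 2 `N#CC1=C(N)Oc2c(N)cc3nc4ccccc4nc3c2C12C(=O)N(Cc1cnnn1-c1ccccc1Cl)c1ccccc12` — > 50000 nM, a limit of the assay

In an ADME assay on HUVEC cells (Homo sapiens) for antiproliferative activity, read by MTT assay, with a stated time of 48 h (a higher number here means a weaker inhibitor, a lower number a stronger inhibitor), compound 1 gives > 50000 nM, which is a limit of the assay and not a number. In this assay compound 2 gives > 50000 nM, again a limit rather than a measured number. Within the data shown here, compound 2 therefore stands at the limit, and the limit of > 50000 nM in this assay, at which 2 of the 2 values shown sit, shows that the other measured compound stands there as well, so no step between measured compounds can be drawn from the numbers on hand.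

The unmeasured compound 3 `COc1ccccc1-n1nncc1CN1C(=O)C2(C(C#N)=C(N)Oc3c(N)cc4nc5ccccc5nc4c32)c2ccccc21` differs from compound 2 by methoxy in place of chloro on an aromatic carbon. Because the limit of > 50000 nM in this assay, at which 2 of the 2 values shown sit, holds for both measured compounds, no step beyond the scatter is expected in this assay, in either direction. Compound 3 is expected to give 50000 nM, within 20000 nM to 150000 nM, and most probably to be reported only as a limit once more. The expected step of a number no higher from compound 2 to compound 3 (the limit leaves the size open) is thus none beyond the scatter.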

Compound 3, half-maximal inhibitory concentration: > 50000 nM
Compound 3 was reported as a limit (the forecaster's own chance of this, stated with the estimate: 85%); the middle value sits exactly at the limit.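

No step can be read between compound 2 and compound 3 in this assay, because both stand only as limits: the limit of > 50000 nM in this assay, at which 3 of the 3 values shown sit.

The compounds shown leave open how 2-chlorophenyl and 2-methoxyphenyl compare in this assay, and whether any compound of this series gives a readable number there.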